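The source may report more compounds than this note shows. Statements on the series, on what has been measured and on what is new or still open speak of the compounds shown alone.

Measured in a functional assay on SSMC-7721 cells (Homo sapiens) for antiproliferative activity, read by CCK-8 assay, with a stated time of 48 h; on this read-out higher numbers stand for weaker inhibition and lower numbers for stronger inhibition:
- compound 1 `O=c1c2ccccc2[se]n1-c1nnc(-c2ccc(Cl)cc2)s1`: 24400 nM
- compound 2 `O=c1c2ccccc2[se]n1-c1nnc(-c2ccc(F)cc2)s1`: 42900 nM
- compound 3 `O=c1c2ccccc2[se]n1-c1nnc(-c2ccccc2Cl)s1`: 40200 nM

Compound 3 stands second highest of the three numbers. Its nearest neighbour is compound 2 a 1.1-fold lower number from compound 2 to compound 3 (0.03 log units; within the scatter); its furthest is compound 1 a 1.6-fold higher number from compound 1 to compound 3 (0.22 log units; within the scatter).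

Compound 4 `O=c1c2ccccc2[se]n1-c1nnc(-c2ccccc2Br)s1` differs from compound 3 in one place: bromo in place of chloro on an aromatic carbon. For the measured compounds named here, the only halogen-for-halogen step measured so far is a 1.8-fold higher number from compound 1 to compound 2 (0.25 log units; within the scatter), fluoro in place of chloro. The remaining steps change the ring position of the chloro, 2-chlorophenyl in place of 4-chlorophenyl, a 1.6-fold higher number from compound 1 to compound 3 (0.22 log units; within the scatter) and a 1.1-fold lower number from compound 2 to compound 3 (0.03 log units; within the scatter). Every measured step sits within the scatter, so no step beyond the scatter is expected in this assay for compound 4 in either direction. Compound 4 is estimated at 40000 nM (range 20000 nM to 80000 nM), an expected step of a 1.0-fold lower number from compound 3 to compound 4 (0.00 log units; within the scatter).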

Compound 4, half-maximal inhibitory concentration: 27400 nM
Compound 4: middle estimate off by 1.5-fold (0.16 log units), on the high side; low and high end bracket the measured number.
By their numbers in this assay, from the lowest: compounds 1, 4, 3 and 2 (each within the scatter of the next).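

In this assay, bromo in place of chloro on this aromatic carbon, ortho to a large group, gives a 1.5-fold lower number from compound 3 to compound 4 (0.17 log units; within the scatter) and so joins fluoro in place of chloro as a halogen swap that stays within the scatter. With 2-bromophenyl in place of either para-free comparison group, a 1.6-fold lower number from compound 2 to compound 4 (0.19 log units; within the scatter) and a 1.1-fold higher number from compound 1 to compound 4 (0.05 log units; within the scatter) likewise stay within the scatter, so the four compounds do not separate in this assay. No measurement bearing on a cause accompanies these numbers. Every compound shown carries a single halogen on this phenyl ring. Going by these compounds, whether an amine, a carboxylic acid or a methoxy group here would give a step beyond the scatter stays open.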